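Changing the Aryl Group on an Amide Nitrogen

The compounds below may be only part of what the source reports. "The series", "measured", "known", "first", "only" and "open" are said of these compounds alone.

Three close relatives have been measured in an in vitro ADME assay on microsomes from liver (Homo sapiens) for pharmacokinetics, read by LC-MS, with a stated time of 10 min, tested at 1 uM; on this read-out higher numbers stand for fast clearance and lower numbers for slow clearance. Compound 1 (`CN1C[C@H](C(=O)Nc2ccc(C#N)cc2)[C@@H](c2ccc(/C=C/C(=O)Nc3ccccc3N)cc2)C1`) gives 1 mL/min/kg, compound 2 (`CN1C[C@H](C(=O)Nc2ccc(C(F)(F)F)cc2)[C@@H](c2ccc(/C=C/C(=O)Nc3ccccc3N)cc2)C1`) gives 6 mL/min/kg, and compound 3 (`CN1C[C@H](C(=O)Nc2ccc(Br)cc2)[C@@H](c2ccc(/C=C/C(=O)Nc3ccccc3N)cc2)C1`) gives 3 mL/min/kg. Compound 3 therefore stands within the scatter of compound 2 but beyond the scatter of compound 1.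

Compound 4 (`CN1C[C@H](C(=O)Nc2ccc(F)c(Cl)c2)[C@@H](c2ccc(/C=C/C(=O)Nc3ccccc3N)cc2)C1`) has not yet been measured. It carries 3-chloro-4-fluorophenyl in place of 4-bromophenyl on an amide-type nitrogen. Among the measured compounds shown here, no measured step makes this exact exchange, and no measured compound carries two groups on this ring, so the evidence is indirect.

The nearest guides are single-group swaps on an aromatic carbon of the same ring. Two steps leave the cyano group of compound 1, and both go beyond the scatter: a 6.0-fold higher number from compound 1 to compound 2 (0.78 log units; beyond the scatter) and a 3.0-fold higher number from compound 1 to compound 3 (0.48 log units; beyond the scatter). The step without cyano, a 2.0-fold lower number from compound 2 to compound 3 (0.30 log units; within the scatter), stays within the scatter. Compound 4 has no cyano group either, so this last step is the closest guide, though an imperfect one. The expected step is a 1.3-fold higher number from compound 3 to compound 4 (0.12 log units; within the scatter), which would not go beyond the scatter. For compound 4 the estimate is 4 mL/min/kg, with an expected range from 1.5 mL/min/kg to 10 mL/min/kg.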

Compound 4, clearance: 15 mL/min/kg
Beside the measured number, compound 4's estimate is 3.8-fold (0.57 log units) below it, outside the stated range (above it).
By their numbers in this assay, from the lowest: compound 1; then compounds 3 and 2 (each within the scatter of the next); then compound 4.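

In this assay, the aryl group on the amide-type nitrogen proves to have a wider reach than the single-group rings suggested: 3-chloro-4-fluorophenyl gives a 5.0-fold higher number from compound 3 to compound 4 (0.70 log units; beyond the scatter), a 2.5-fold higher number from compound 2 to compound 4 (0.40 log units; beyond the scatter) and a 15-fold higher number from compound 1 to compound 4 (1.18 log units; beyond the scatter), so the new ring stands clear of all three earlier ones, and the last of these steps is the only large one in the set. The earlier compounds shown here differ by one group on this ring, whereas this change replaces the bromo group with a chloro and a fluoro group together, so a ring carrying two groups can sit well outside the span that the single-group rings cover. Nothing shown here explains why clearance climbs with this ring.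

The compounds shown leave open whether the chloro group, the fluoro group or the pair accounts for the higher number, as no ring here carries either one alone. They also leave open how a ring bearing a methoxy group or an amine would behave at this position, or whether a saturated ring such as cyclohexyl could take the place of the aryl group.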